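Sulfo on the hydroxymethyl of compound 1

The source may report more compounds than this note shows. Statements on the series, on what has been measured and on what is new or still open speak of the compounds shown alone.

Measured in a functional assay on U-373MG ATCC cells (Homo sapiens), read by thymidine incorporation; on this read-out higher numbers stand for weaker inhibition and lower numbers for stronger inhibition:
Compound 1 `CCCCCCCC/C=C\CCCCCCCC(=O)N[C@H]1[C@@H](OCCCCCCCC)O[C@H](CO)[C@@H](O)[C@@H]1O` gives 13.3 uM
Compound 2 `CCCCCCCC/C=C\CCCCCCCC(=O)N[C@H]1[C@@H](OCCCCCCCC)O[C@H](CO)[C@@H](O)[C@@H]1OS(=O)(=O)O` gives 15.6 uM

Only these two compounds have been measured, and compound 1 has no clear place above or below compound 2. Among the measured compounds shown here, the one step between them is a 1.2-fold higher number from compound 1 to compound 2 (0.07 log units; within the scatter), which lies within the scatter, so the two values set no order.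

Compound 3 `CCCCCCCC/C=C\CCCCCCCC(=O)N[C@H]1[C@@H](OCCCCCCCC)O[C@H](COS(=O)(=O)O)[C@@H](O)[C@@H]1O` has yet to be measured. It differs from compound 1 by sulfo in place of hydrogen on an oxygen on a saturated carbon, which is sulfo in place of hydrogen on an oxygen on a saturated carbon, or hydroxymethyl to (sulfooxy)methyl.

The step to compound 2 is the only measured one that bears on this. It is the same kind of replacement, made on a different oxygen, so it is a guide and not a direct precedent. For the measured compounds named here, with only that step to go on, no change beyond the scatter is expected in this assay. The expected step is a 1.1-fold higher number from compound 1 to compound 3 (0.05 log units; within the scatter). Compound 3 is estimated at 15 uM, with an expected range from 7 uM to 30 uM.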

Compound 3, concentration for 50% inhibition: 12.6 uM
The estimate for compound 3 lay 1.2-fold (0.08 log units) above the measured number; the measured number falls inside the stated range.
By their numbers in this assay, from the lowest: compounds 3, 1 and 2 (each within the scatter of the next).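

In this assay, sulfo in place of hydrogen has now been read on the hydroxymethyl oxygen itself, and this gives a 1.1-fold lower number from compound 1 to compound 3 (0.02 log units; within the scatter) and so sets no order between the two compounds. The earlier result, a 1.2-fold higher number from compound 1 to compound 2 (0.07 log units; within the scatter), came from a different oxygen and could only serve as a guide, whereas there are now two separate sites on the core of compound 1 where this replacement leaves the number within the scatter, with each of compound 2 and compound 3 read only against compound 1. Nothing available explains why hydroxymethyl to (sulfooxy)methyl leaves the number where it is.

From the compounds shown here alone, it remains open whether sulfo on both of these oxygens in a single compound would also stay within the scatter of compound 1. Going by these compounds, it is equally open whether a different group in place of the hydroxymethyl, such as an amine or a carboxylic acid, would move the number beyond the scatter, since only the sulfo replacement has been read at this position.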